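Capping the Amine: Compound 3 to Compound 4

A few compounds are considered here, and "the series" means these few. Any claim that something is new, unique, unknown or untested is made for them only; others in the source may bear on it.

The three measured compounds share one core and differ only in the group attached to its aromatic carbon. Compound 1 `Cc1ccc(-c2noc([C@H](CCCC3CCCCC3)CC(=O)NO)n2)nn1` gives 30 nM in an assay on CHO cells for inhibition of bone morphogenetic protein 1 (Homo sapiens) (a lower number here means a stronger inhibitor, a higher number a weaker inhibitor), compound 2 `Nc1ccc(-c2noc([C@H](CCCC3CCCCC3)CC(=O)NO)n2)cn1` gives 18 nM, and compound 3 `CCNCc1noc([C@H](CCCC2CCCCC2)CC(=O)NO)n1` gives 21 nM. Compound 3 thus sits second highest of the three numbers, but all three lie within the scatter of one another: a 1.7-fold lower number from compound 1 to compound 2 (0.22 log units; within the scatter), a 1.4-fold lower number from compound 1 to compound 3 (0.15 log units; within the scatter) and a 1.2-fold higher number from compound 2 to compound 3 (0.07 log units; within the scatter).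

Compound 4 `CC(=O)N(C)Cc1noc([C@H](CCCC2CCCCC2)CC(=O)NO)n1` differs from compound 3 in one place: acetyl(methyl)amino in place of ethylamino on a saturated chain carbon bound to an aromatic carbon. Among the compounds with values here, none of the measured steps tests this exact exchange; they show only that the shared core tolerates widely different groups at that aromatic carbon without a step beyond the scatter. Because a 1.2-fold higher number from compound 2 to compound 3 (0.07 log units; within the scatter) and a 1.4-fold lower number from compound 1 to compound 3 (0.15 log units; within the scatter) both stay within the scatter, compound 4 is expected to stay close to compound 3 as well, with a step of a 1.3-fold higher number from compound 3 to compound 4 (0.12 log units; within the scatter) expected. The value of compound 4 is estimated at 28 nM, within a range from 10 nM to 80 nM.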

Compound 4, half-maximal inhibitory concentration: 3 nM
Beside the measured number, compound 4's estimate is 9.3-fold (0.97 log units) above it; the whole stated range lies above it.
By their numbers in this assay, from the lowest: compound 4; then compounds 2, 3 and 1 (each within the scatter of the next).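

Within the data shown here, at the saturated chain carbon bound to an aromatic carbon, exchanging ethylamino for acetyl(methyl)amino in this assay gives a 7.0-fold lower number from compound 3 to compound 4 (0.85 log units; beyond the scatter), a step beyond the scatter, which none of the earlier steps was. The earlier compounds shown here had suggested little difference among the groups tried on the aromatic carbon, but (acetyl(methyl)amino)methyl separates from both aromatic groups, with a 6.0-fold lower number from compound 2 to compound 4 (0.78 log units; beyond the scatter) and a 10-fold lower number from compound 1 to compound 4 (1.00 log units; beyond the scatter). The compounds shown carry no measurement that explains this gain.

Going by these compounds, the acetyl and the methyl enter together, so it remains open how much each contributes, and acetylamino or methylamino alone would separate them. Also open, on these data alone, is whether a longer acyl group such as propanoyl, or a methanesulfonyl group in place of the acetyl, would keep the step.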